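The source may hold more compounds than are shown below. What is called first, only, known or untested is meant among the compounds shown, and "the series" means these compounds.

Measured so far in a functional assay on DLD-1 cells (Homo sapiens) for antiproliferative activity, read by CellTiter-Glo, with a stated time of 72 h; on this read-out lower numbers stand for stronger inhibition and higher numbers for weaker inhibition:

compound 1 `CC1CCN(C2CCN(S(=O)(=O)c3ccc(C#N)cc3)CC2)CC1`: 2800 nM
compound 2 `CC1CCN(C2CCN(S(=O)(=O)c3ccc(Br)cc3OC(F)(F)F)CC2)CC1`: 5 nM
compound 3 `C#CCCC(=O)CC1CCN(C2CCN(S(=O)(=O)c3c(C)cc(C)cc3C)CC2)CC1`: 3 nM

Compound 2 holds the second highest of the three numbers. Its nearest neighbour is compound 3, whose number lies within the scatter of it; its furthest is compound 1, far higher and well beyond the scatter. Compound 4 `CCc1cc(Br)ccc1S(=O)(=O)N1CCC(N2CCC(C)CC2)CC1` is not yet measured. It differs from compound 2 in one place: ethyl in place of trifluoromethoxy on an aromatic carbon. The aromatic ring keeps its bromo group and keeps a substituent ortho to the sulfonyl, so the step from compound 2 to compound 4 in this assay is expected to be small, at most a modest rise, a 2.4-fold higher number from compound 2 to compound 4 (0.38 log units; beyond the scatter), because compound 2 sits at 5 nM with that pattern intact. Compound 4 is therefore estimated at 12 nM, within 3 nM to 50 nM.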

Compound 4, half-maximal inhibitory concentration: 0.6 nM
Compound 4: the middle estimate sits 20-fold (1.30 log units) above what was measured; measured number outside the range, below it.
By their numbers in this assay, from the lowest: compound 4; then compounds 3 and 2 (each within the scatter of the next); then compound 1.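

In this assay, ethyl in place of trifluoromethoxy gives an 8.3-fold lower number from compound 2 to compound 4 (0.92 log units; beyond the scatter) and so shows that this position, ortho to a large group, does not need trifluoromethoxy for a low number. For the compounds shown here, the earlier compounds offered no pair differing in one place, so this is the only step that can be read at this position. No measured data bear on what lies behind this step.

From the compounds shown here alone, whether methyl, methoxy or a longer chain such as propyl at this position would give a lower or higher number remains open. So does whether the step holds with chloro in place of the bromo group.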